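From 2-hydroxyphenyl to thiophen-3-yl on a shared core

This account rests on a few compounds, and the source may have more. Where it says the series, first, only, none or still open, it means among the compounds named here.

Three compounds share one core and differ in the group on a saturated ring carbon. In a functional assay on B16-F10 cells (Mus musculus) for antiproliferative activity, read by MTT assay, with a stated time of 48 h (a lower number here means a stronger inhibitor, a higher number a weaker inhibitor), compound 1 `CC(=O)N1N=C(c2ccc3ccccc3c2)OC1c1ccc(Cl)cc1`, with 4-chlorophenyl, gives 2.48 ug/mL. Compound 2 `CC(=O)N1N=C(c2ccc3ccccc3c2)OC1c1ccccc1[N+](=O)[O-]`, with 2-nitrophenyl, gives 9.01 ug/mL. Compound 3 `CC(=O)N1N=C(c2ccc3ccccc3c2)OC1c1ccccc1O`, with 2-hydroxyphenyl, gives 2.58 ug/mL, which places it level with compound 1 and well apart from compound 2.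

The next step leads to compound 4 `CC(=O)N1N=C(c2ccc3ccccc3c2)OC1c1ccsc1`, which carries thiophen-3-yl in place of 2-hydroxyphenyl on a saturated ring carbon. Among the compounds with values here, no measured compound carries this group, so the evidence is only indirect. Exchanging the group at this place has given a 1.0-fold higher number from compound 1 to compound 3 (0.02 log units; within the scatter), but also a 3.6-fold higher number from compound 1 to compound 2 (0.56 log units; beyond the scatter) and a 3.5-fold lower number from compound 2 to compound 3 (0.54 log units; beyond the scatter). These steps show that a change here can leave the number unmoved or shift it modestly, and only compound 2 stands apart. In this assay, no step beyond the scatter is therefore expected, with a slight lean towards a higher number and room for a modest rise. The expected change is a 1.2-fold higher number from compound 3 to compound 4 (0.09 log units; within the scatter). For compound 4 the estimated value is 3.2 ug/mL, with an expected range of 1.3 ug/mL to 8.5 ug/mL.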

Compound 4, half-maximal inhibitory concentration: 8.56 ug/mL
Beside the measured number, compound 4's estimate is 2.7-fold (0.43 log units) below it, outside the stated range (above it).
By their numbers in this assay, from the lowest: compounds 1 and 3 (each within the scatter of the next); then compounds 4 and 2 (each within the scatter of the next).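

In this assay, thiophen-3-yl does not behave like 2-hydroxyphenyl or 4-chlorophenyl at this position, with a 3.3-fold higher number from compound 3 to compound 4 (0.52 log units; beyond the scatter) and a 3.5-fold higher number from compound 1 to compound 4 (0.54 log units; beyond the scatter), so a change here can cost as much without any nitro group being present. Compound 2 therefore no longer stands alone, since the result is a 1.1-fold lower number from compound 2 to compound 4 (0.02 log units; within the scatter), and the four compounds now fall into two sets, compounds 1 and 3 at the lower numbers and compounds 2 and 4 at the higher ones, each set sharing no single group. Nothing measured here gives a reason for this split, and neither ring size nor ring substitution alone sorts the compounds, as compound 2 keeps the six-membered aromatic ring yet joins compound 4.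

The compounds shown leave open whether the step to compound 4 follows from the five-membered ring containing sulfur or from the loss of a substituent on the ring, a question that plain phenyl at this place would help to separate. They also leave open how thiophen-2-yl or furan-3-yl, or an amine such as 4-aminophenyl, would sit against these two sets.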